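A few compounds are considered here, and "the series" means these few. Any claim that something is new, unique, unknown or untested is made for them only; others in the source may bear on it.

Compound 1 `O=C(NC[C@@H]1[C@H]2CN(C(=O)OCc3cc(Cl)cc(Cl)c3)C[C@@H]12)c1ccc2[nH]c(=O)oc2c1`: < 1 ug/mL (a limit)
Compound 2 `O=C(NC[C@@H]1[C@H]2CN(C(=O)/C=C/c3cc(Cl)cc(Cl)c3)C[C@@H]12)c1ccc2[nH]c(=O)oc2c1`: < 1 ug/mL (a limit)
Compound 3 `O=C(NC[C@@H]1[C@H]2CN(C(=O)C3CC3c3cc(Cl)cc(Cl)c3)C[C@@H]12)c1ccc2[nH]c(=O)oc2c1`: < 1 ug/mL (a limit)

In a physicochemical assay for solubility, with a stated time of 24 h, at pH 6.8 (a lower number here means a less soluble compound, a higher number a more soluble compound), compound 3 stands at < 1 ug/mL, which is a limit and not a number. The same is true of the whole series, with the limit of < 1 ug/mL in this assay, at which 3 of the 3 values shown sit.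

Compound 4 `O=C(NC[C@@H]1[C@H]2CN(C(=O)NCc3cc(Cl)cc(Cl)c3)C[C@@H]12)c1ccc2[nH]c(=O)oc2c1` differs from compound 3 by a group of 10 heavy atoms (7 carbon, 1 nitrogen, 2 chlorine; one six-membered aromatic ring of carbon only) in place of a group of 11 heavy atoms (9 carbon, 2 chlorine; one three-membered non-aromatic ring of carbon only, one six-membered aromatic ring of carbon only), on a carbonyl carbon. The entering group is (3,5-dichlorobenzyl)amino, on a carbonyl carbon whose other neighbours are an amide-type nitrogen in a ring.

The measured steps that bear on this are a step that the two limits leave unreadable from compound 1 to compound 3, a step that the two limits leave unreadable from compound 2 to compound 3 and a step that the two limits leave unreadable from compound 1 to compound 2. None of them has a readable size, so they support no direction of change. The expected step is a number no lower from compound 3 to compound 4 (the limit leaves the size open), with nothing anticipated beyond the usual scatter. Compound 4 is estimated at 1 ug/mL, with an expected range of 0.5 ug/mL to 4 ug/mL.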

Compound 4, solubility: < 1 ug/mL
Compound 4: a limit, no number; the forecaster's own chance of this, stated with the estimate: 70%; the middle value sits exactly at the limit.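

Compound 4 gives a limit and not a number, as do compound 1, compound 2 and compound 3, so none of its steps to those compounds can be read. The compounds shown leave open how these four rank in solubility, with every value resting on one limit: the limit of < 1 ug/mL in this assay, at which 4 of the 4 values shown sit.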